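Swapping an aryl group for cyclopropyl on a shared core

A few compounds are considered here, and "the series" means these few. Any claim that something is new, unique, unknown or untested is made for them only; others in the source may bear on it.

Measured so far:
compound 1 `Cc1nn(C)c2nc(NNC(=O)Nc3cc(Cl)nc(Cl)c3)cc(-c3ccc(Cl)s3)c12`: 42100 nM
compound 2 `COc1ccc(-c2cc(NNC(=O)Nc3cc(Cl)nc(Cl)c3)nc3c2c(C)nn3C)cc1`: 82300 nM

Both compounds were tested in a functional assay on HCT-116 cells (Homo sapiens) for cytotoxicity, read by MTT assay, with a stated time of 48 h, in the presence of a further agent that is not named here; a lower number here means that less compound is needed, a higher number that more compound is needed for the effect. Compound 1 gives 42100 nM, and compound 2 gives 82300 nM. Among the two numbers, compound 2 has the highest, with compound 1 nearest; the step of a 2.0-fold higher number from compound 1 to compound 2 (0.29 log units; within the scatter) lies within the scatter, so the two compounds cannot be told apart on these data.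

Compound 3 `Cc1nn(C)c2nc(NNC(=O)Nc3cc(Cl)nc(Cl)c3)cc(C3CC3)c12` has not yet been measured. It differs from compound 2 in one place: cyclopropyl in place of 4-methoxyphenyl on an aromatic carbon. Among the measured compounds shown here, the only step measured so far, a 2.0-fold higher number from compound 1 to compound 2 (0.29 log units; within the scatter), exchanged one aromatic ring for another at this same position and did not move the number beyond the scatter. For the measured compounds named here, no measured step covers the exchange of an aromatic ring for a small non-aromatic ring, so the expectation rests on the single step seen and on the fact that both measured compounds sit at high numbers. On that basis the step of a 1.0-fold higher number from compound 2 to compound 3 (0.01 log units; within the scatter) is expected to stay within the scatter. Compound 3 is therefore estimated at 85000 nM, with a range from 30000 nM to 250000 nM.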

Compound 3, half-maximal effective concentration: 67700 nM
Compound 3: middle estimate off by 1.3-fold (0.10 log units), on the high side; the range from low to high includes it.
By their numbers in this assay, from the lowest: compounds 1, 3 and 2 (each within the scatter of the next).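

In this assay, the first non-aromatic ring at this position, opposite the ring nitrogen, gives a 1.2-fold lower number from compound 2 to compound 3 (0.08 log units; within the scatter) and also a 1.6-fold higher number from compound 1 to compound 3 (0.21 log units; within the scatter), so neither step can be told from the scatter. Until now this position had carried only aromatic rings, and the two measured groups could have shared a need for such a ring; the much smaller cyclopropyl, with no aromatic ring and no hydrogen-bond acceptor, shows that on these data neither feature is needed to keep the number where it stands. With three different groups here and no step beyond the scatter, the position has not yet shown any effect of the group it carries on this read-out, and nothing at hand explains why.

The compounds shown leave open whether a group of another kind at this position, such as an amine, a carboxylic acid or a longer alkyl chain, would move the number beyond the scatter. They also leave open whether any change here can bring the number down, since all three compounds share the rest of the structure and only this one position varies.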